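Amino in place of chloro on the core of compound 2

This account rests on a few compounds, and the source may have more. Where it says the series, first, only, none or still open, it means among the compounds named here.

Compound 1 `ClCc1cccc(Cn2cnc3c(Cl)ncnc32)c1` gives 7620 nM in a functional assay on CCRF-CEM cells (Homo sapiens) for cytotoxicity, read by sulforhodamine B assay, with a stated time of 48 h; a higher number here means that more compound is tolerated, a lower number that less compound is tolerated. Compound 2 `ClCc1cccc(Cn2cnc3c(Cl)nc(Cl)nc32)c1` carries a second chloro on the same core. For compound 2 this assay reports only a limit, > 100000 nM; this is the limit of > 100000 nM in this assay, at which 1 of the 3 values shown sits, so compound 2 stands on that limit alone, with no number beneath it. Compound 3 `ClCc1ccc(Cn2cnc3c(Cl)nc(Cl)nc32)cc1` is a positional isomer of compound 2. In this assay compound 3 gives 14100 nM.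

Within the data shown here, the only measured step at the place in question is an at least 13-fold higher number from compound 1 to compound 2 (1.11 log units; beyond the scatter). Among the measured compounds shown here, no measured pair exchanges chloro for amino, so the direction of such a swap cannot be read off directly.

Compound 4 `Nc1nc(Cl)c2ncn(Cc3cccc(CCl)c3)c2n1` differs from compound 2 by amino in place of chloro on an aromatic carbon. The amino takes out the chloro whose entry drove the large step above, and what sits at this place evidently moves the numbers strongly; the hydrogen analogue, compound 1, stands far below the limit. For compound 4 the expected step is an at least 3.3-fold lower number from compound 2 to compound 4 (0.52 log units; beyond the scatter), its size uncertain since it starts from a limit. Compound 4 is therefore expected to give about 30000 nM in this assay, with a range from 7000 nM to 130000 nM.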

Compound 4, concentration lethal to 50% of the cells: > 100000 nM
Compound 4: only a limit was reported; the forecaster's own chance of this, stated with the estimate: 35%; middle value at least 3.3-fold (0.52 log units) from the limit.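

In this assay compound 4 stands on a limit and not on a number, the same place as compound 2: the limit of > 100000 nM in this assay, at which 2 of the 4 values shown sit. Amino in place of hydrogen on the aromatic carbon between two ring nitrogen atoms gives an at least 13-fold higher number from compound 1 to compound 4 (1.11 log units; beyond the scatter), so the large step seen with chloro, an at least 13-fold higher number from compound 1 to compound 2 (1.11 log units; beyond the scatter), is not confined to chloro: with either group at this place the reading reaches the limit, and only the hydrogen of compound 1 keeps a number there. The direct swap of chloro for amino cannot be read, with a limit on both sides, so the two groups cannot be ranked against each other in this series.

Still open, going by these compounds, is whether amino in place of chloro at this place holds on the positional isomer compound 3, which gives 14100 nM, a true number from which such a step could be read. Also open, on these data alone, is whether a methyl or a methoxy at this place goes to the limit as well or stays measurable like the hydrogen of compound 1.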